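The compounds below may be only part of what the source reports. "The series", "measured", "known", "first", "only" and "open" are said of these compounds alone.

Measured so far in a functional assay on MDA-MB-231 cells (Homo sapiens) for cytotoxicity, read by MTT assay, with a stated time of 48 h; a higher number here means a weaker inhibitor, a lower number a stronger inhibitor:
Compound 1 `COc1ccccc1Nc1nc(-c2cccc(F)c2)nc2ccc(F)cc12`: > 50000 nM, a limit.
Compound 2 `Fc1cccc(-c2nc(Nc3ccccc3F)c3cc(F)ccc3n2)c1`: > 50000 nM, a limit.

Compound 2 thus has no number, only a limit, shared with compound 1: the limit of > 50000 nM in this assay, at which 2 of the 2 values shown sit. Among the compounds with values here, the sole measured step is a step that the two limits leave unreadable from compound 1 to compound 2, with fluoro in place of methoxy on an aromatic carbon. Compound 3 `Fc1cccc(-c2nc(Nc3cccc(Cl)c3)c3cc(F)ccc3n2)c1` remains unmeasured. It differs from compound 2 as follows: 3-chlorophenyl in place of 2-fluorophenyl on a nitrogen on an aromatic ring. That is 3-chlorophenyl in place of 2-fluorophenyl on a nitrogen on an aromatic ring. With no readable size to carry over from a step that the two limits leave unreadable from compound 1 to compound 2, only a small shift toward stronger inhibition in this assay is expected, and the expected step is an at least 1.2-fold lower number from compound 2 to compound 3 (0.09 log units; that floor lies within the scatter). Compound 3 is estimated at 40000 nM, with an expected range of 10000 nM to 100000 nM.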

Compound 3, half-maximal inhibitory concentration: > 50000 nM
Compound 3 gave a limit, no number; the forecaster's own chance of this, stated with the estimate: 60%; at least 1.2-fold (0.09 log units) between middle value and limit.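

Compound 3 gave only a limit, as did compound 1 and compound 2, so no step among them can be read: the limit of > 50000 nM in this assay, at which 3 of the 3 values shown sit.

The compounds shown leave open whether exchanging the group on the nitrogen changes the cytotoxicity at all.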